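Ester arm one carbon longer: compound 3 to compound 4

The source may report more compounds than this note shows. Statements on the series, on what has been measured and on what is new or still open speak of the compounds shown alone.

The three measured compounds share one core and differ only in the group at the far end of the sulfur-linked chain. In an assay on HEK293 cells for displacement of a labelled ligand from prostaglandin D2 receptor 2 (Homo sapiens) (a lower number here means a stronger inhibitor, a higher number a weaker inhibitor), compound 1 `O=C(O)Cn1c(SCCCOc2ccccc2)nc2ccccc21` gives 786 nM. Compound 2 `O=C(O)Cn1c(SCCCc2ccccc2)nc2ccccc21` gives 475 nM in this assay. Compound 3 `CCOC(=O)CCCCSc1nc2ccccc2n1CC(=O)O` gives 2360 nM in this assay and carries the highest number of the three, with compound 1 nearest and compound 2 furthest.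

The measured steps all exchange the terminal group at a fixed distance from the sulfur: a 1.7-fold lower number from compound 1 to compound 2 (0.22 log units; within the scatter); a 3.0-fold higher number from compound 1 to compound 3 (0.48 log units; beyond the scatter); a 5.0-fold higher number from compound 2 to compound 3 (0.70 log units; beyond the scatter). The two steps that reach compound 3 are modest and beyond the scatter; the step between compound 1 and compound 2 is within it.

Compound 4 `CCOC(=O)CCCCCSc1nc2ccccc2n1CC(=O)O` is not yet measured. The change from compound 3 is (ethoxycarbonyl)methyl in place of ethoxycarbonyl on a saturated chain carbon, four bonds along the chain from a sulfur. Within the data shown here, no measured step lengthens the chain while keeping the terminal group, so none bears directly on this change; the measured steps only show that the terminal group itself shifts the number modestly. The expectation is therefore a step of no more than the scatter, a 1.2-fold lower number from compound 3 to compound 4 (0.07 log units; within the scatter), in either direction. Compound 4 is estimated at 2000 nM in this assay, with a range of 900 nM to 5000 nM.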

Compound 4, half-maximal inhibitory concentration: 1010 nM
Compound 4: the middle estimate sits 2.0-fold (0.30 log units) above what was measured; the range from low to high includes it.
By their numbers in this assay, from the lowest: compounds 2, 1 and 4 (each within the scatter of the next, the first and the last beyond it); then compound 3.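

Working notes on the ester arm. In this assay, among these compounds, one added carbon in the ester arm gives a step beyond the scatter (a 2.3-fold lower number from compound 3 to compound 4 (0.37 log units; beyond the scatter)), so the length of the arm at this position moves the number, whereas the earlier steps exchanged only the terminal group at a fixed distance from the sulfur. The longer ester arm also changes how the ester stands against the two aromatic end groups: the 2-(ethoxycarbonyl)ethyl group in place of phenoxy stays within the scatter (a 1.3-fold higher number from compound 1 to compound 4 (0.11 log units; within the scatter)), while in place of phenyl it remains beyond the scatter (a 2.1-fold higher number from compound 2 to compound 4 (0.33 log units; beyond the scatter)), so a terminal group with no ring can match compound 1 but not compound 2 in this set. No measurement shown here offers a cause for the effect of the added carbon.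

The compounds shown leave open whether a still longer chain carrying the same ethyl ester continues in the direction of this step or reverses it. They also leave open what a carboxylic acid or an amide in place of the ester would give at this chain length, and whether a phenyl group on a longer chain responds to the added carbon as the ester arm does.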